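The source may hold more compounds than are shown below. What is called first, only, known or untested is meant among the compounds shown, and "the series" means these compounds.

Four compounds share one core and differ at two places. Compound 1 `CNc1ncnc2c1c(I)cn2[C@@H]1O[C@H](CO)[C@@H](O)[C@H]1O` carries methylamino and iodo. In a functional assay on HeLa S3 cells (Homo sapiens) for antiproliferative activity, read by XTT assay, with a stated time of 72 h (on this read-out higher numbers stand for weaker inhibition and lower numbers for stronger inhibition), compound 1 gives > 20000 nM, which is a limit of the assay rather than a number. Compound 2 `COc1ncnc2c1c(I)cn2[C@@H]1O[C@H](CO)[C@@H](O)[C@H]1O` differs from compound 1 in one place, (methoxy in place of methylamino on an aromatic carbon), and in this assay compound 2 gives 14300 nM. That change made an at least 1.3-fold lower number from compound 1 to compound 2 (0.14 log units; that floor lies within the scatter); the step is only a floor because compound 1 sits at the limit of > 20000 nM in this assay, at which 1 of the 3 values shown sits. Compound 3 `CNc1ncnc2c1c(-c1ccco1)cn2[C@@H]1O[C@H](CO)[C@@H](O)[C@H]1O` differs from compound 1 at the other place, and in this assay compound 3 gives 5000 nM; that change made an at least 4.0-fold lower number from compound 1 to compound 3 (0.60 log units; beyond the scatter). Of the two compounds with a number, compound 3 has the lower one, and compound 2 lies beyond the scatter above it.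

Compound 4 `COc1ncnc2c1c(-c1ccco1)cn2[C@@H]1O[C@H](CO)[C@@H](O)[C@H]1O` has not yet been measured. It differs from compound 3 by methoxy in place of methylamino on an aromatic carbon, the same change that turned compound 1 into compound 2, made here on the core of compound 3, which differs from the core of compound 1 by furan-2-yl in place of iodo on an aromatic carbon. The earlier step of this change was a floor within the scatter, so from compound 3 to compound 4 a similar small step is expected, a 1.3-fold lower number from compound 3 to compound 4 (0.10 log units; within the scatter). On that basis compound 4 is estimated at 4000 nM in this assay, expected to fall between 1500 nM and 12000 nM.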

Compound 4, half-maximal inhibitory concentration: 1020 nM
Compound 4: middle estimate off by 3.9-fold (0.59 log units), on the high side; measured number outside the range, below it.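

In this assay the exchange of methylamino for methoxy gives a 4.9-fold lower number from compound 3 to compound 4 (0.69 log units; beyond the scatter) on the core carrying furan-2-yl, and the exchange of iodo for furan-2-yl gives a 14-fold lower number from compound 2 to compound 4 (1.15 log units; beyond the scatter) on the core carrying methoxy, so compound 4 has the lowest number of those that can be read. The methoxy change points the same way on both cores, but this does not show that its size depends on the core, since the step on the iodo core is only a floor and the larger step on the furan-2-yl core cannot be called a real gain over it: the same change on two cores in this assay, an at least 1.3-fold lower number (0.14 log units; that floor lies within the scatter) from compound 1 to compound 2 and a 4.9-fold lower number (0.69 log units; beyond the scatter) from compound 3 to compound 4; the limit leaves it open whether they differ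

The same caution holds for the furan-2-yl change, which also lowers the number on both cores without showing that the two changes reinforce each other: the same change on two cores in this assay, an at least 4.0-fold lower number (0.60 log units; beyond the scatter) from compound 1 to compound 3 and a 14-fold lower number (1.15 log units; beyond the scatter) from compound 2 to compound 4; the limit leaves it open whether they differ

Going by these compounds alone, with only two cores, these four compounds cannot say whether the methoxy change would carry over to a core with a phenyl or thiophene ring in place of furan-2-yl. They also leave open how an ethoxy group, a longer chain or an unsubstituted amine would behave in the place now held by methoxy or methylamino.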